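Compound 3: 4-methoxyphenyl replaces 2,4,6-trimethylphenyl

This account rests on a few compounds, and the source may have more. Where it says the series, first, only, none or still open, it means among the compounds named here.

Among the measured compounds shown here, in a functional assay on HCT-116 cells (Homo sapiens) for antiproliferative activity, read by MTT assay (a lower number here means a stronger inhibitor, a higher number a weaker inhibitor), compound 1 (`COc1cccc(/C=N/Nc2ncc3c(n2)n(C2CCCC2)c(=O)c(=O)n3C)c1`) gives 45800 nM and compound 2 (`Cc1cc(C)c(/C=N/Nc2ncc3c(n2)n(C2CCCC2)c(=O)c(=O)n3C)c(C)c1`) gives 7920 nM as the lower of the two numbers so far. Compound 3 (`COc1ccc(/C=N/Nc2ncc3c(n2)n(C2CCCC2)c(=O)c(=O)n3C)cc1`) has 4-methoxyphenyl in place of 2,4,6-trimethylphenyl on a carbon with a double bond to nitrogen. For the measured compounds named here, the only measured step, a 5.8-fold lower number from compound 1 to compound 2 (0.76 log units; beyond the scatter) for 2,4,6-trimethylphenyl in place of 3-methoxyphenyl, is modest and beyond the scatter. Returning to a methoxyphenyl therefore points to a similar move upward in this assay with an expected 3.8-fold higher number from compound 2 to compound 3 (0.58 log units; beyond the scatter) as the working figure. Compound 3 is estimated at 30000 nM with an expected range from 10000 nM to 80000 nM for now.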

Compound 3, half-maximal inhibitory concentration: 36100 nM
Beside the measured number, compound 3's estimate is 1.2-fold (0.08 log units) below it; low and high end bracket the measured number.
By their numbers in this assay, from the lowest: compound 2; then compounds 3 and 1 (each within the scatter of the next).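

In this assay, the two methoxyphenyl compounds cannot be told apart: a 1.3-fold lower number from compound 1 to compound 3 (0.10 log units; within the scatter) for 4-methoxyphenyl in place of 3-methoxyphenyl, a step that stays within the scatter. Compound 2 stands apart from this second methoxyphenyl compound as well, with a 4.6-fold higher number from compound 2 to compound 3 (0.66 log units; beyond the scatter). No evidence on the cause of either step is at hand.

Still open, going by these compounds, is whether a plain phenyl, or a phenyl carrying an amine or a carboxylic acid, would read like compound 2 or like the methoxyphenyl pair.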